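From Compound 2 to Compound 4: A Changed Chain End

The compounds below may be only part of what the source reports. "The series", "measured", "known", "first", "only" and "open" are said of these compounds alone.

Of the compounds shown here, three with a shared core have been measured in a functional assay on MDA-MB-231 cells (Homo sapiens) for cytotoxicity, read by MTT assay, with a stated time of 38 h; a lower number here means a stronger inhibitor, a higher number a weaker inhibitor. Compound 1 `COc1cc(OC)c2c(=O)c(OCC(=O)N/N=C/c3sccc3C)c(-c3cc(OC)c(OC)c(OC)c3)oc2c1` gives 4470 nM, compound 3 `COc1cc(OC)c2c(=O)c(OCCCCN3CCCCC3)c(-c3cc(OC)c(OC)c(OC)c3)oc2c1` gives 3030 nM, and compound 2 `COc1cc(OC)c2c(=O)c(OCCCCN3CCCC3)c(-c3cc(OC)c(OC)c(OC)c3)oc2c1` gives 10400 nM. That last number is the highest of the three, which makes compound 2 the weakest inhibitor in this small set.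

Compound 4 `COc1cc(OC)c2c(=O)c(OCCCN3CCN(C)CC3)c(-c3cc(OC)c(OC)c(OC)c3)oc2c1` has not yet been measured. It differs from compound 2 at the end of the side chain: 4-methylpiperazin-1-yl in place of (pyrrolidin-1-yl)methyl on a saturated chain carbon, three bonds along the chain from an oxygen on an aromatic ring. In words, 4-methylpiperazin-1-yl stands in place of (pyrrolidin-1-yl)methyl on a saturated chain carbon, three bonds along the chain from an oxygen on an aromatic ring.

The closest measured change is a 3.4-fold lower number from compound 2 to compound 3 (0.54 log units; beyond the scatter), where piperidin-1-yl replaces pyrrolidin-1-yl. Two other steps involve the quite different chain end of compound 1: a 2.3-fold higher number from compound 1 to compound 2 (0.37 log units; beyond the scatter) and a 1.5-fold lower number from compound 1 to compound 3 (0.17 log units; within the scatter). For the measured compounds named here, no measured compound carries 4-methylpiperazin-1-yl, so these steps are only a rough guide. They suggest that compound 2 sits toward the weak end, and a small move toward a lower number seems likely.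

In this assay the expected change is a 1.9-fold lower number from compound 2 to compound 4 (0.28 log units; within the scatter). For compound 4 the estimate is 5500 nM, with an expected range of 2200 nM to 12000 nM.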

Compound 4, half-maximal inhibitory concentration: 30100 nM
The estimate for compound 4 lay 5.5-fold (0.74 log units) below the measured number; the whole stated range lies below it.
By their numbers in this assay, from the lowest: compounds 3 and 1 (each within the scatter of the next); then compound 2; then compound 4.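

In this assay a change at the chain end can also push the number up, which the earlier swap of piperidin-1-yl for pyrrolidin-1-yl did not show: 3-(4-methylpiperazin-1-yl)propyl in place of 4-(pyrrolidin-1-yl)butyl gives a rise (a 2.9-fold higher number from compound 2 to compound 4 (0.46 log units; beyond the scatter)). The rise is larger when measured from the other two compounds (a 9.9-fold higher number from compound 3 to compound 4 (1.00 log units; beyond the scatter); a 6.7-fold higher number from compound 1 to compound 4 (0.83 log units; beyond the scatter)), which leaves compound 4 as the weakest inhibitor of the four in this small set. Nothing among the data shown accounts for this loss of activity.

The step from compound 2 to compound 4 alters the ring at the chain end and the length of the chain together, so these numbers cannot say how much of the rise belongs to each change. A 4-(4-methylpiperazin-1-yl)butyl chain, which pairs the new ring with the longer chain, or a 3-(pyrrolidin-1-yl)propyl chain, which pairs the old ring with the shorter chain, would pull the two changes apart on the shared core.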